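This account rests on a few compounds, and the source may have more. Where it says the series, first, only, none or still open, it means among the compounds named here.

Measured compounds in a functional assay on SR cells (Homo sapiens) for antiproliferative activity, with a stated time of 48 h; a higher number here means a weaker inhibitor of growth, a lower number a stronger inhibitor of growth:
- compound 1, `Cc1cc(O)c(C2=NN(c3ccc(S(N)(=O)=O)cc3)C(/C=C/c3ccccc3)C2)cc1Cl`: 33800 nM
- compound 2, `COc1ccc(C2CC(c3cc(Cl)c(C)cc3O)=NN2c2ccc(S(N)(=O)=O)cc2)cc1OC`: 100000 nM

Among the measured compounds shown here, compound 2 holds the highest of the two numbers in this assay; its nearest neighbour is compound 1, and the step of a 3.0-fold higher number from compound 1 to compound 2 (0.47 log units; beyond the scatter) is the only one the pair of measurements allows. That step swaps the 2-phenylethenyl group on the saturated ring carbon for 3,4-dimethoxyphenyl, and it moved the number modestly upward.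

Compound 3, `COc1ccc(C2CC(c3cc(Cl)c(C)cc3O)=NN2c2ccc(S(N)(=O)=O)cc2)c(OC)c1OC`, keeps the whole of compound 2 and differs only in one spot: methoxy in place of hydrogen on an aromatic carbon. In words, the 3,4-dimethoxyphenyl becomes 2,3,4-trimethoxyphenyl.

For the measured compounds named here, no measured step covers an added methoxy on this aromatic ring. Going by the values given here, the single step available, from the phenylethenyl group to the dimethoxyphenyl group, concerns a different change and gives no direct guide; it only shows that this assay already reads compound 2 at the high end of the two numbers. With nothing to argue for a sharp move, the expected step of a 1.1-fold lower number from compound 2 to compound 3 (0.05 log units; within the scatter) is small, inside the usual scatter. The estimate for compound 3 in this assay is therefore 90000 nM, with a range from 35000 nM to 150000 nM.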

Compound 3, concentration for total growth inhibition: 7350 nM
Estimate against measurement, compound 3: 12-fold (1.09 log units) above; the whole stated range lies above it.
By their numbers in this assay, from the lowest: compound 3; then compound 1; then compound 2.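

In this assay, the methoxy on an aromatic carbon, ortho to a large group and ortho to a methoxy group, gives a 14-fold lower number from compound 2 to compound 3 (1.13 log units; beyond the scatter), so a single substituent at this position on the ring moves the number far more than the modest first step in the series. The added methoxy also reverses the order relative to the 2-phenylethenyl compound: 3,4-dimethoxyphenyl had given a higher number than that group, whereas 2,3,4-trimethoxyphenyl gives a 4.6-fold lower number from compound 1 to compound 3 (0.66 log units; beyond the scatter). Nothing available accounts for the size of this change.

Still open, as far as these compounds go, is whether the methoxy at this carbon would give a step of this size without the two neighbouring methoxy groups, or whether the step depends on all three being present. Also open, from the compounds shown here alone, is whether another group at the same carbon, such as hydroxyl, fluorine, ethoxy or an amine, would lower the number in this assay as far as methoxy does, or whether this response is specific to methoxy.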